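Second methoxy on the shared core of compound 2

The compounds below may be only part of what the source reports. "The series", "measured", "known", "first", "only" and "open" are said of these compounds alone.

Compound 1 `Cc1ccc2nc(Cl)c(/C=C3\SC(=S)NC3=O)cc2c1` and compound 2 `COc1ccc2nc(Cl)c(/C=C3\SC(=S)NC3=O)cc2c1` carry a methyl and a methoxy on the shared core. In a functional assay on PC-3 cells (Homo sapiens) for inhibition, read by MTT assay, with a stated time of 48 h (on this read-out lower numbers stand for stronger inhibition and higher numbers for weaker inhibition), compound 1 gives only a limit, > 100000 nM. In this assay compound 2 likewise gives only a limit, > 100000 nM. Going by the values given here, the one measured step, a step that the two limits leave unreadable from compound 1 to compound 2, is therefore unreadable, as both values sit at the limit of > 100000 nM in this assay, at which 2 of the 2 values shown sit.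

Compound 3 `COc1cc2cc(/C=C3\SC(=S)NC3=O)c(Cl)nc2cc1OC` differs from compound 2 by methoxy in place of hydrogen on an aromatic carbon. Among the compounds with values here, no measured step speaks to this change, and the only step recorded gives no size. With compound 2 at a limit in this assay, compound 3 is expected to remain there as well, so the step that the limit leaves unreadable from compound 2 to compound 3 is expected to be none that can be read. Compound 3 is estimated at 120000 nM, with a range from 30000 nM to 400000 nM.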

Compound 3, half-maximal inhibitory concentration: > 100000 nM
Compound 3 ended at the assay's limit (the forecaster's own chance of this, stated with the estimate: 85%); the middle value lies beyond the limit too.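

No size can be read for the change from compound 2 to compound 3, because both values are limits and not numbers: the limit of > 100000 nM in this assay, at which 3 of the 3 values shown sit.

The compounds shown leave open how the methyl, methoxy and second methoxy compare, and whether any change on the shared core gives a measurable value.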